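Compound 2 to compound 3: losing the 4-(hydroxymethyl)phenyl

The source may report more compounds than this note shows. Statements on the series, on what has been measured and on what is new or still open speak of the compounds shown alone.

Measured so far in an ADME assay on HepG2 cells (Homo sapiens) for cytotoxicity, read by MTT assay, with a stated time of 72 h; a higher number here means that more compound is tolerated, a lower number that less compound is tolerated:
Compound 1 `Nc1ccc(C#Cc2cc(Cl)cn3c([N+](=O)[O-])c(CS(=O)(=O)c4ccccc4)nc23)cc1` gives > 3900 nM as a limit
Compound 2 `O=[N+]([O-])c1c(CS(=O)(=O)c2ccccc2)nc2c(C#Cc3ccc(CO)cc3)cc(Cl)cn12` gives > 15600 nM as a limit

Compound 2 stands only at a limit, > 15600 nM as reported, with no number behind it. Compound 1 also gives only a limit, > 3900 nM as reported, so neither value can be read as a number. Within the data shown here, the one measured step, a step that the two limits leave unreadable from compound 1 to compound 2, exchanges amino for hydroxymethyl on an aromatic carbon and offers no size to carry forward. Compound 3 `O=[N+]([O-])c1c(CS(=O)(=O)c2ccccc2)nc2c(C#CCO)cc(Cl)cn12` puts hydroxymethyl in place of the 4-(hydroxymethyl)phenyl of compound 2 on a triple-bonded carbon hydroxymethyl in place of 4-(hydroxymethyl)phenyl on a triple-bonded carbon and thereby loses the six-membered aromatic ring of carbon only. Among the measured compounds shown here, no measured step removes that ring. No step beyond the scatter is therefore expected in this assay, and no direction is assumed. The expected step is a number no higher from compound 2 to compound 3 (the limit leaves the size open) as estimated here. For compound 3 the estimate is 15600 nM, with an expected range from 6000 nM to 40000 nM and a fair chance of another limit.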

Compound 3, half-maximal cytotoxic concentration: 10100 nM
Compound 3: middle estimate off by 1.5-fold (0.19 log units), on the high side; the range from low to high includes it.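

In this assay, among these compounds, compound 3 gives 10100 nM, the first value that is a number and not a limit. Hydroxymethyl in place of 4-(hydroxymethyl)phenyl on the triple-bonded carbon gives an at least 1.5-fold lower number from compound 2 to compound 3 (0.18 log units; that floor lies within the scatter), so the six-membered aromatic ring is lost with no step shown beyond the scatter, though that floor does not rule one out. Compound 1 stands only at a limit, so its step to compound 3 cannot be read: the limit of > 3900 nM in this assay, at which 1 of the 3 values shown sits.

Compound 2 is also held at a limit, > 15600 nM, which leaves open how large the step to the shorter group really is. Also open, from the compounds shown here alone, is how a dimethylaminomethyl group or a carboxylic acid on the triple-bonded carbon would read in this assay.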